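Swapping the indole of compound 2 for a methoxyphenyl

The compounds below may be only part of what the source reports. "The series", "measured", "known", "first", "only" and "open" are said of these compounds alone.

Measured compounds in a functional assay on A549 cells (Homo sapiens) for inhibition, read by CCK-8 assay, with a stated time of 48 h; on this read-out lower numbers stand for stronger inhibition and higher numbers for weaker inhibition:
compound 1 `Cn1ccc2cc(-c3cc4nccc(-c5ccc(F)cc5)n4n3)ccc21` gives 3520 nM
compound 2 `COc1cc(-c2ccnc3cc(-c4ccc5c(ccn5C)c4)nn23)cc(OC)c1OC` gives 15 nM
compound 3 `COc1cc(-c2ccnc3cc(-c4cn(C(=O)OC(C)(C)C)c5ccccc45)nn23)cc(OC)c1OC` gives 2070 nM

Compound 2 has the lowest number of the three in this assay, and its gaps to compound 3 and to compound 1 both lie beyond the scatter. Compound 4 `COc1ccc(-c2cc3nccc(-c4cc(OC)c(OC)c(OC)c4)n3n2)cc1` has not yet been measured. It differs from compound 2 in one place: 4-methoxyphenyl in place of 1-methyl-1H-indol-5-yl on an aromatic carbon. Among the compounds with values here, no measured pair separates this change on its own, so the size of the step is uncertain. Since compound 1, which keeps the indole but alters the other aryl group, gives 3520 nM, the indole is not by itself sufficient, and a loss of some size is expected in this assay on its removal, the estimated step being a 10-fold higher number from compound 2 to compound 4 (1.00 log units; beyond the scatter). Compound 4 is therefore expected to give about 150 nM, within 30 nM to 1000 nM.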

Compound 4, half-maximal inhibitory concentration: 376 nM
Estimate against measurement, compound 4: 2.5-fold (0.40 log units) below; low and high end bracket the measured number.
By their numbers in this assay, from the lowest: compound 2; then compound 4; then compounds 3 and 1 (each within the scatter of the next).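

In this assay, within the data shown here, exchanging 1-methyl-1H-indol-5-yl for 4-methoxyphenyl on this aromatic carbon gives a 25-fold higher number from compound 2 to compound 4 (1.40 log units; beyond the scatter), the first step to isolate this position, and it is large. The single-ring group therefore does not match the indole here, so the group at this position strongly affects the read-out when the rest of the molecule is unchanged. No available evidence accounts for the size of this step. The compounds shown leave open whether the loss follows from the missing five-membered ring or from the methoxy group. They also leave open what an amine in place of that methoxy would give.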